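The source may hold more compounds than are shown below. What is called first, only, known or untested is meant among the compounds shown, and "the series" means these compounds.

Compound 1 `COc1ccc(C(=O)c2ccc3c(ccn3S(=O)(=O)c3cccc(/C=C/C(=O)NO)c3)c2)cc1` gives 812 nM in an assay on isolated protein for inhibition of histone deacetylase 8 (Homo sapiens) (on this read-out higher numbers stand for weaker inhibition and lower numbers for stronger inhibition), the lowest of the three numbers recorded. Compound 3 `O=C(NO)c1ccc(Cn2ccc3cc(C(=O)c4ccc(F)cc4)ccc32)cc1` gives 1240 nM, a number that lies within the scatter of that of compound 1, so no order between the two can be claimed. Compound 2 `COc1cc(C(=O)c2ccc3c(ccn3S(=O)(=O)c3ccc(/C=C/C(=O)NO)cc3)c2)cc(OC)c1OC` gives 5340 nM, a gap beyond the scatter. Compound 4 `COc1cccc(C(=O)c2ccc3c(ccn3S(=O)(=O)c3cccc(/C=C/C(=O)NO)c3)c2)c1` has not yet been measured. It differs from compound 1 in one place: 3-methoxyphenyl in place of 4-methoxyphenyl on a carbonyl carbon. Among the compounds with values here, no step between measured compounds of this kind has been recorded, so the direction is uncertain; a step no larger than the scatter is expected, the estimated step being a 1.1-fold higher number from compound 1 to compound 4 (0.04 log units; within the scatter). Compound 4 is therefore expected to give about 900 nM, with a range from 350 nM to 2400 nM.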

Compound 4, half-maximal inhibitory concentration: 3530 nM
Beside the measured number, compound 4's estimate is 3.9-fold (0.59 log units) below it; the whole stated range lies below it.
By their numbers in this assay, from the lowest: compounds 1 and 3 (each within the scatter of the next); then compounds 4 and 2 (each within the scatter of the next).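

In this assay 3-methoxyphenyl in place of 4-methoxyphenyl on a carbonyl carbon brings a 4.3-fold higher number from compound 1 to compound 4 (0.64 log units; beyond the scatter) and so shows that this position responds to where the methoxy group sits, even though the two groups have the same atoms and the same counts. The earlier compounds shown here offered no comparison of this kind, as none of them differed in only one place. No measured evidence on the origin of this step is at hand. The compounds shown leave open how a plain phenyl, or an ethoxy or hydroxyl group in place of the methoxy group, would read here. Going by these compounds, whether the same change would give a similar step on other compounds also remains open.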